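This account rests on a few compounds, and the source may have more. Where it says the series, first, only, none or still open, it means among the compounds named here.

Compound 3 `O=C(Nc1ccccc1)c1cn(-c2ccccc2)nc1-c1ccc(Cl)cc1` gives 2180 nM in a functional assay on HCT-116 cells (Homo sapiens) for cytotoxicity, read by MTT assay, with a stated time of 48 h (a lower number here means a stronger inhibitor, a higher number a weaker inhibitor), the second highest of the three numbers measured. Its nearest neighbour is compound 2 `Cc1ccc(-c2nn(-c3ccccc3)cc2C(=O)Nc2ccccc2)cc1`, which gives 2360 nM in this assay; the step of a 1.1-fold lower number from compound 2 to compound 3 (0.03 log units; within the scatter) is within the scatter. Compound 1 `COc1ccc(NC(=O)c2cn(-c3ccccc3)nc2-c2ccccc2)cc1`, which carries a methoxy on the anilide ring, gives 1350 nM in this assay, and its gap to compound 3 is also within the scatter.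

Compound 4 `COc1ccc(NC(=O)c2cn(-c3ccccc3)nc2-c2ccc(Cl)cc2)cc1` differs from compound 3 by methoxy in place of hydrogen on an aromatic carbon. Among the measured compounds shown here, no measured step isolates this change: compound 1 and compound 3 differ in two places, so their values show only that a methoxy-bearing anilide and a chloro-bearing aryl both sit within the scatter of each other. For the measured compounds named here, the one measured step, from compound 2 to compound 3, concerns the other ring and was itself within the scatter. The step of a 1.3-fold lower number from compound 3 to compound 4 (0.11 log units; within the scatter) in this assay is therefore expected to stay within the scatter, if anything slightly towards a lower number. Compound 4 is estimated at 1700 nM in this assay, with a range from 700 nM to 4000 nM.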

Compound 4, half-maximal inhibitory concentration: 1330 nM
Compound 4: middle estimate off by 1.3-fold (0.11 log units), on the high side; the measured number falls inside the stated range.
By their numbers in this assay, from the lowest: compounds 4, 1, 3 and 2 (each within the scatter of the next).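

In this assay, among the compounds shown here, the step of a 1.6-fold lower number from compound 3 to compound 4 (0.21 log units; within the scatter) gives the first direct reading of methoxy in place of hydrogen on the anilide ring, on an aromatic carbon para to a large group, and this change stays within the scatter with chloro present on the other aryl ring. The step of a 1.0-fold lower number from compound 1 to compound 4 (0.01 log units; within the scatter) gives the matching reading for chloro in place of hydrogen with methoxy present, and it also stays within the scatter, so neither single change separates these compounds in this read-out. No independent data bear on the origin of these small steps.

On these data alone, whether an amine or a carboxylic acid in place of the methoxy would give a step beyond the scatter remains open. The same holds for a longer chain, such as ethoxy or butoxy, at that place.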